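The source may hold more compounds than are shown below. What is called first, only, known or untested is meant among the compounds shown, and "the series" means these compounds.

Compound 2 `CCO/N=C/c1ccc(OCCC(C)CCN2CCN(c3ccccc3)C2=O)cc1` and its closest measured neighbour, compound 1 `CCO/N=C/c1ccc(OCCC(C)CCN2CCN(c3ccnc(OC)c3)C2=O)cc1`, share the whole of their structure apart from the group on the amide-type nitrogen of the five-membered ring. In an ADME assay on RD cells (Homo sapiens) for cytotoxicity, read by MTT assay, with a stated time of 24 h (a higher number here means that more compound is tolerated, a lower number that less compound is tolerated), compound 1 gives > 100000 nM, which is a limit of the assay and not a number. In this assay compound 2 gives > 100000 nM, also a limit. Within the data shown here, the step that the two limits leave unreadable from compound 1 to compound 2 is therefore not readable, and the only evidence is the limit of > 100000 nM in this assay, at which 2 of the 2 values shown sit. Compound 3 `CCO/N=C/c1ccc(OCCC(C)CCN2CCN(c3ccnc(O)c3)C2=O)cc1` differs from compound 2 by 2-hydroxypyridin-4-yl in place of phenyl on an amide-type nitrogen in a ring. Among the measured compounds shown here, no measured step bears on this exchange with a readable size, so the tolerance of compound 2 sits at the ceiling of the measurement, and compound 3 is expected to stay there. For compound 3 the expected value is 150000 nM, with a range from 50000 nM to 400000 nM. The expected step that the limit leaves unreadable from compound 2 to compound 3 is thus one of no change beyond the scatter.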

Compound 3, half-maximal cytotoxic concentration: > 100000 nM
Compound 3 ended at the assay's limit (the forecaster's own chance of this, stated with the estimate: 80%); the middle value lies beyond the limit too.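

The steps from compound 2 to compound 3 and from compound 1 to compound 3 cannot be read, since all three compounds end at the same limit in this assay: the limit of > 100000 nM in this assay, at which 3 of the 3 values shown sit.

The compounds shown leave open whether the group on the amide-type nitrogen changes tolerance at all.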